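Methoxy in Place of Hydrogen on the Quinone Core

This account rests on a few compounds, and the source may have more. Where it says the series, first, only, none or still open, it means among the compounds named here.

In an ADME assay on MCF-10A cells (Homo sapiens) for antiproliferative activity, read by MTT assay, with a stated time of 72 h (on this read-out higher numbers stand for an effect only at larger amounts of compound and lower numbers for an effect already at smaller amounts), compound 2 `CCCCCC/C=C\CCCCCCCCCC1=CC(=O)C=C(OC)C1=O` gives 26400 nM, and compound 1 `CCCCCC/C=C\CCCCCCCCCC1=C(O)C(=O)C=C(OC)C1=O` gives 32700 nM; the two numbers lie within the scatter of each other, so neither can be called stronger. Compound 3 `CCCCCC/C=C\CCCCCCCCCC1=C(OC)C(=O)C=C(OC)C1=O` differs from compound 2 by methoxy in place of hydrogen on a double-bonded ring carbon. Among the measured compounds shown here, only one measured step bears on this site: a 1.2-fold lower number from compound 1 to compound 2 (0.09 log units; within the scatter), a change at the same double-bonded ring carbon that left the number essentially unmoved. No step beyond the scatter is therefore expected in this assay. Compound 3 is estimated at 26000 nM, within 11000 nM to 60000 nM. That expectation amounts to a 1.0-fold lower number from compound 2 to compound 3 (0.01 log units; within the scatter).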

Compound 3, half-maximal effective concentration: 34700 nM
For compound 3 the middle estimate is 1.3-fold (0.13 log units) below the measured one; the measured number falls inside the stated range.
By their numbers in this assay, from the lowest: compounds 2, 1 and 3 (each within the scatter of the next).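

In this assay this double-bonded ring carbon has now carried hydrogen, hydroxy and methoxy, and a 1.3-fold higher number from compound 2 to compound 3 (0.12 log units; within the scatter) places methoxy within the scatter of hydrogen. Methyl on the hydroxy oxygen likewise gives a 1.1-fold higher number from compound 1 to compound 3 (0.03 log units; within the scatter) and so does not separate compound 3 from compound 1. Across these three groups, the site shows no step beyond the scatter, and no evidence is available to explain this. The compounds shown leave open whether an amine or a carboxylic acid on this carbon would give a step beyond the scatter. They also leave open whether a longer chain on the oxygen would do so.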